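Fluoro in place of methyl: expectation for compound 3

The compounds below may be only part of what the source reports. "The series", "measured", "known", "first", "only" and "open" are said of these compounds alone.

Of the compounds shown here, two so far carry numbers in an assay on isolated protein for inhibition of Amine oxidase [flavin-containing] B (Homo sapiens); a lower number here means a stronger inhibitor, a higher number a weaker inhibitor. Compound 1 `C#CCNC1CCc2c(NCc3cccc(C(F)(F)F)c3)cccc21` gives 5110 nM in this assay. Within the data shown here, compound 2 `C#CCNC1CCc2c(SCCc3cccc(C)c3)cccc21` gives 0.35 nM in this assay, the lowest of the two numbers; compound 1 is its only neighbour and stands far higher, well beyond the scatter. Among the measured compounds shown here, no pair of measured compounds differs in one place only, so the series carries no calibrated single step yet.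

Compound 3 `C#CCNC1CCc2c(SCCc3cccc(F)c3)cccc21` is not yet measured. It differs from compound 2 by fluoro in place of methyl on an aromatic carbon: one heavy atom exchanged for one heavy atom, with no ring and no donor or acceptor added or removed. Nothing in the series fixes the size of such an exchange, so a small step is expected in this assay, namely a 1.7-fold higher number from compound 2 to compound 3 (0.23 log units; within the scatter), within the scatter or only slightly toward a higher number. Compound 3 is accordingly expected to give about 0.6 nM in this assay, with a range from 0.15 nM to 3 nM.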

Compound 3, half-maximal inhibitory concentration: 4300 nM
Beside the measured number, compound 3's estimate is 7200-fold (3.86 log units) below it, and the stated range ends below it.
By their numbers in this assay, from the lowest: compound 2; then compounds 3 and 1 (each within the scatter of the next).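

In this assay, the exchange of 3-methylphenyl for 3-fluorophenyl gives the series its first calibrated single step, a 12000-fold higher number from compound 2 to compound 3 (4.09 log units; beyond the scatter), and that step is large. This place on the aromatic ring, meta to a large group, is therefore highly sensitive in this series: fluoro in place of methyl swaps one heavy atom for one heavy atom, with no ring, hydrogen-bond donor, hydrogen-bond acceptor or net charge added, yet the number changes far beyond the scatter. No measurement shown here accounts for the size of this step.

Still open, on these data alone, is whether chloro, ethyl or methoxy in the same place would give a number near that of compound 2 or near that of compound 3. This single pair also leaves open whether the step keeps its size with a longer chain linking the sulfur to the aromatic ring.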